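The source may hold more compounds than are shown below. What is called first, only, known or untested is meant among the compounds shown, and "the series" means these compounds.

Of the compounds shown here, three have been measured in a functional assay on MIA PaCa-2 cells (Homo sapiens) for antiproliferative activity, read by MTT assay, with a stated time of 72 h; on this read-out higher numbers stand for an effect only at larger amounts of compound and lower numbers for an effect already at smaller amounts. Compound 1 `Cc1nn(Cc2ccccc2)c(C)c1NC(=O)c1ccc(COc2ccccc2)cc1` gives 10000 nM. Compound 2 `Cc1nn(Cc2cccc(C(N)=O)c2)c(C)c1NC(=O)c1ccc(COc2ccccc2)cc1` carries carbamoyl in place of hydrogen on an aromatic carbon and gives 9200 nM; the step of a 1.1-fold lower number from compound 1 to compound 2 (0.04 log units; within the scatter) lies within the scatter. Compound 3 `CNC(=O)c1cccc(Cn2nc(C)c(NC(=O)c3ccc(COc4cccc(C)c4)cc3)c2C)c1` gives 6200 nM. Compound 3 thus shows the smallest of the three numbers, but its gap to compound 2 and its gap to compound 1 both stay within the scatter of repeated measurements, so the three compounds cannot be ordered with confidence.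

Compound 4 `CNC(=O)c1cccc(Cn2nc(C)c(NC(=O)c3ccc(COc4cccc(OC)c4)cc3)c2C)c1` is not yet measured. It differs from compound 3 in one place: methoxy in place of methyl on an aromatic carbon. Among the measured compounds shown here, no measured pair shows this exchange, so no step bears on it directly. For the measured compounds named here, the only single-place step on record, from compound 1 to compound 2, changed a different part of the molecule and stayed within the scatter, and compounds 2 and 3, which differ in two places, also lie within the scatter of each other. On this record a small exchange at the outer phenoxy ring is expected to move this assay little, if at all: the expected step of a 1.0-fold lower number from compound 3 to compound 4 (0.01 log units; within the scatter) stays within the scatter. Compound 4 is therefore estimated at 6000 nM, with a range from 2500 nM to 15000 nM.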

Compound 4, half-maximal effective concentration: 6200 nM
The estimate for compound 4 lay 1.0-fold (0.01 log units) below the measured number, within the range that was stated.
By their numbers in this assay, from the lowest: compounds 3, 4, 2 and 1 (each within the scatter of the next).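

Among the compounds shown here, this is the first single-place exchange on record at the outer phenoxy ring, since the only earlier step altered the other end of the molecule. In this assay, going from 3-methylphenoxy to 3-methoxyphenoxy gives no change at the digits printed from compound 3 to compound 4 (within the scatter) as its step, so at this aromatic carbon, meta to a large group, the reading does not separate methyl from methoxy, even though the methoxy group brings in an oxygen that methyl lacks. Nothing at hand bears on the reason for this reading.

What this pair shows is limited to two small groups at one ring position, so it cannot be stretched to the ring as a whole or to other substituents placed elsewhere on it. Going by these compounds, whether an amine, a carboxylic acid or a longer chain such as butoxy at this same carbon would also stay within the scatter of compound 3, or would instead move the number clearly, remains open.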